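The source may report more compounds than this note shows. Statements on the series, on what has been measured and on what is new or still open speak of the compounds shown alone.

Working notes on the series. Compound 1 `CC1NC(NCCC2CCCCC2)=Nc2ccccc21` carries a cyclohexylethyl group on the amine nitrogen of the shared core; in an assay on isolated protein for binding affinity to 5-hydroxytryptamine receptor 5A (Homo sapiens) (on this read-out higher numbers stand for weaker inhibition and lower numbers for stronger inhibition), compound 1 gives 124 nM. Compound 2 `CC1NC(NC2CCC2)=Nc2ccccc21` carries a cyclobutyl group at the same nitrogen, and in this assay compound 2 gives 122 nM. Compound 2 thus sits alongside compound 1, the two numbers falling within the usual scatter of each other, so nothing separates the two substituents on this read-out.

Compound 3 `CCCNC1=Nc2ccccc2C(C)N1` is not yet measured. The change from compound 2 is propyl in place of cyclobutyl on an amine nitrogen. For the measured compounds named here, no step between measured compounds is known for this change, but because compound 1 at 124 nM and compound 2 at 122 nM agree despite very different groups on this nitrogen, the step of a 1.2-fold higher number from compound 2 to compound 3 (0.09 log units; within the scatter) is expected to stay within the scatter, with no clear direction. Compound 3 is expected at 150 nM, within the range 60 nM to 400 nM.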

Compound 3, inhibition constant: 153 nM
Beside the measured number, compound 3's estimate is 1.0-fold (0.01 log units) below it; measured number inside the range.
By their numbers in this assay, from the lowest: compounds 2, 1 and 3 (each within the scatter of the next).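

In this assay, the ring is not needed at this position: propyl in place of cyclobutyl on the amine nitrogen gives a 1.3-fold higher number from compound 2 to compound 3 (0.10 log units; within the scatter). The longer comparison reads the same way, with methyl in place of cyclohexyl on a saturated chain carbon, two bonds along the chain from an amine nitrogen, giving a 1.2-fold higher number from compound 1 to compound 3 (0.09 log units; within the scatter), so cyclobutyl, cyclohexylethyl and propyl on this nitrogen all stand within the scatter of one another. No evidence at hand bears on why this position tolerates such different groups.

On these data alone, whether this flat response extends to a chain ending in a carboxylic acid or an amine, or to a phenyl group on the same nitrogen, stays open. Also open, as far as these compounds go, is whether any change at this nitrogen moves the number beyond the scatter.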